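Aryl change on the ring amine nitrogen, compound 1 to 3

A few compounds are considered here, and "the series" means these few. Any claim that something is new, unique, unknown or untested is made for them only; others in the source may bear on it.

Two compounds in this set carry numbers. In a functional assay on CHO cells with adenosine receptor A1 (Homo sapiens) as the target, read by cAMP accumulation and immunoassay, with a stated time of 6 min, tested at 0.1 uM (a higher number here means a weaker effect of the compound at the concentration tested, a lower number a stronger effect), compound 1 `Nc1scc(CN2CCN(c3ccccc3C(F)(F)F)CC2)c1C(=O)c1ccc(Cl)cc1` gives -7.5%, the higher of the two numbers; in this assay compound 2 `Nc1scc(CN2CCN(c3cccc(F)c3)CC2)c1C(=O)c1cccc(C(F)(F)F)c1` gives -12%, which lies within the scatter of compound 1, so the two are not separated. Compound 3 `Nc1scc(CN2CCN(c3ccc(F)c(Cl)c3)CC2)c1C(=O)c1ccc(Cl)cc1` differs from compound 1 by 3-chloro-4-fluorophenyl in place of 2-(trifluoromethyl)phenyl on an amine nitrogen in a ring. Among the compounds with values here, no measured pair shows this change, so it has no precedent here. As compound 1 gives -7.5% with essentially no effect, the step is expected to stay within the scatter: a number 0.5 percentage points lower from compound 1 to compound 3 (within the scatter). Compound 3 is expected to give -8% in this assay, within -25% to 12%.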

Compound 3, a percentage reported as activity, at one concentration (the size of the read-out at that concentration, not a potency): -21%
Compound 3: the middle estimate sits 13 percentage points above what was measured; low and high end bracket the measured number.
By their numbers in this assay, from the lowest: compounds 3, 2 and 1 (each within the scatter of the next, the first and the last beyond it).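

In this assay, within the data shown here, 3-chloro-4-fluorophenyl in place of 2-(trifluoromethyl)phenyl on the amine nitrogen in the ring gives a number 13.5 percentage points lower from compound 1 to compound 3 (beyond the scatter), the first step here to separate two compounds. The aryl group at this position therefore changes the read-out while the rest of compound 1 stays the same. No supporting data bear on why the number moves.

From the compounds shown here alone, both the trifluoromethyl group and the chlorine and fluorine change in this single step, so their shares remain open. Also open, going by these compounds, is how an unsubstituted phenyl or a pyridine ring on this nitrogen would read.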